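A few compounds are considered here, and "the series" means these few. Any claim that something is new, unique, unknown or untested is made for them only; others in the source may bear on it.

Measured so far in a functional assay on A549 cells (Homo sapiens) for antiproliferative activity, with a stated time of 6 days; a lower number here means a stronger inhibitor of growth, a higher number a weaker inhibitor of growth:
compound 1 `Cc1ccc(S(=O)(=O)Nc2ccc(-c3ccccc3)c3cccnc23)cc1` gives 2360 nM
compound 2 `Cc1ccc(S(=O)(=O)Nc2ccc(-c3ccco3)c3cccnc23)cc1` gives 26000 nM
compound 3 `Cc1ccc(S(=O)(=O)Nc2cc(Oc3cc(F)cc(F)c3)cc3cccnc23)cc1` gives 4110 nM

Among these three numbers compound 3 stands second highest; its nearest neighbour is compound 1, within the scatter, while compound 2 lies further off, beyond it. The step to compound 4 `Cc1ccc(S(=O)(=O)Nc2cc(Oc3cccc(C#N)c3)cc3cccnc23)cc1` is 3-cyanophenyl in place of 3,5-difluorophenyl on an oxygen on an aromatic ring. Among the measured compounds shown here, the only step measured so far, an 11-fold higher number from compound 1 to compound 2 (1.04 log units; beyond the scatter), exchanges a whole ring on an aromatic carbon, a different place from the oxygen changed here, so it does not bear on this step. For the measured compounds named here, no measured step speaks to the present change, and no shift beyond the scatter is therefore expected in this assay. Compound 4 is estimated at 4500 nM, with a range from 1500 nM to 14000 nM. That estimate means an expected step of a 1.1-fold higher number from compound 3 to compound 4 (0.04 log units; within the scatter).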

Compound 4, concentration for 50% growth inhibition: 6480 nM
Compound 4: middle estimate off by 1.4-fold (0.16 log units), on the low side, and the stated range covers the measured number.
By their numbers in this assay, from the lowest: compounds 1, 3 and 4 (each within the scatter of the next, the first and the last beyond it); then compound 2.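

In this assay, among the compounds shown here, 3-cyanophenyl in place of 3,5-difluorophenyl on the oxygen gives a 1.6-fold higher number from compound 3 to compound 4 (0.20 log units; within the scatter) and is the first measured step at this place. Here, a ring carrying a nitrile and a ring carrying two fluorines give numbers that stay within the scatter of each other. Nothing measured here explains this result.

Still open, from the compounds shown here alone, is how this ring responds to an amine or a carboxylic acid in place of the nitrile. Also open, going by these compounds, is whether the oxygen linking it to the core could be exchanged for a nitrogen-hydrogen link.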